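Bis-chromone analogues in a cell growth assay

The source may hold more compounds than are shown below. What is called first, only, known or untested is meant among the compounds shown, and "the series" means these compounds.

Compound 1 `O=c1c(/C=C/c2coc3ccccc3c2=O)coc2ccccc12`: > 10000 nM, a limit of the assay.
Compound 2 `CC(C)COc1cccc2occ(Cc3coc4ccccc4c3=O)c(=O)c12`: > 10000 nM, a limit of the assay.
Compound 3 `O=c1c(CCc2coc3ccccc3c2=O)coc2ccccc12`: > 10000 nM, a limit of the assay.

In a functional assay on HCT-15 cells (Homo sapiens) for antiproliferative activity, read by XTT assay (a lower number here means a stronger inhibitor, a higher number a weaker inhibitor), compound 2 gives only a limit, not a number. The same holds for every value shown, as the limit of > 10000 nM in this assay, at which 3 of the 3 values shown sit, states, so compound 2 cannot be placed above or below the others. Compound 4 `O=c1c(Cc2coc3cccc(OCc4ccccc4)c3c2=O)coc2ccccc12` differs from compound 2 by phenyl in place of isopropyl on a saturated chain carbon bound to an oxygen on an aromatic ring. Among the measured compounds shown here, with no measured step to lean on, no change beyond the scatter is expected, and compound 4 is expected to stay at the limit as well. The estimate for compound 4 is 20000 nM, within 5000 nM to 100000 nM, which means an expected step that the limit leaves unreadable from compound 2 to compound 4.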

Compound 4, half-maximal inhibitory concentration: > 10000 nM
Compound 4 ended at the assay's limit; the forecaster's own chance of this, stated with the estimate: 85%; the middle value does not contradict the limit.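

In this assay, among the compounds shown here, compound 2 and compound 4 both give only a limit, so no step between them can be read. On these data alone, whether phenyl in place of isopropyl changes activity at all remains open.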